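Open-Chain Amine in Place of Pyrrolidine on Compound 3

The source may hold more compounds than are shown below. What is called first, only, known or untested is meant among the compounds shown, and "the series" means these compounds.

Compound 1, `O=c1cc(CSC(=S)N2CCCCC2)oc2cc(Cl)ccc12`, gives 1600 nM in a functional assay on HEp-2 cells (Homo sapiens) for antiproliferative activity, read by MTT assay, with a stated time of 72 h; on this read-out higher numbers stand for weaker inhibition and lower numbers for stronger inhibition.
Compound 2, `O=c1cc(CSC(=S)N2CCCC2)oc2ccccc12`, gives 9100 nM in this assay.
Compound 3, `O=c1cc(CSC(=S)N2CCCC2)oc2cc(Cl)ccc12`, reaches only a limit of this assay, > 40000 nM.

Compound 3 thus stands at the weak end of the three, with no number of its own, at the limit of > 40000 nM in this assay, at which 1 of the 3 values shown sits. Two measured steps lead to it: an at least 25-fold higher number from compound 1 to compound 3 (1.39 log units; beyond the scatter), and an at least 4.3-fold higher number from compound 2 to compound 3 (0.64 log units; beyond the scatter). Compound 4, `CCN(CC)C(=S)SCc1cc(=O)c2ccc(Cl)cc2o1`, differs from compound 3 by diethylamino in place of pyrrolidin-1-yl on a thiocarbonyl carbon. Going by the values given here, the first of these steps shows that the amine on the thiocarbonyl carbon can move the number strongly, but no measured pair compares an open chain with a ring there. Compound 4 is therefore expected near where compound 3 sits, with a modest improvement possible. The expected step is an at least 1.6-fold lower number from compound 3 to compound 4 (0.20 log units; that floor lies within the scatter). Compound 4 is estimated at 25000 nM, ranging from 4000 nM to 80000 nM.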

Compound 4, half-maximal inhibitory concentration: 8800 nM
Compound 4: the middle estimate sits 2.8-fold (0.45 log units) above what was measured; the measured number falls inside the stated range.
By their numbers in this assay, from the lowest: compound 1; then compounds 4 and 2 (each within the scatter of the next). At a limit, above all of these: compound 3.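

Going by these compounds alone, an open chain on the thiocarbonyl carbon, set against a ring for the first time, gives an at least 4.5-fold lower number from compound 3 to compound 4 (0.65 log units; beyond the scatter) on the same core. Compound 3 holds only a limit, so that step is a floor. Yet an open chain is not simply better than a ring: piperidin-1-yl holds the lower number, with a 5.5-fold higher number from compound 1 to compound 4 (0.74 log units; beyond the scatter) when diethylamino replaces it.

As far as these compounds go, whether morpholin-4-yl or dimethylamino at this place would stand nearer compound 1 or compound 4 stays open. So does how diethylamino behaves on the core of compound 2, which carries no chloro.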